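The source may hold more compounds than are shown below. What is called first, only, known or untested is meant among the compounds shown, and "the series" means these compounds.

Working notes on the series. In a functional assay on HCT-116 cells (Homo sapiens) for antiproliferative activity, read by MTT assay, with a stated time of 48 h (on this read-out lower numbers stand for stronger inhibition and higher numbers for weaker inhibition), compound 1 `O=C(/C=C/c1cccc(NC(=O)c2ccccc2Br)c1)c1nc2ccccc2[nH]1` gives 1680 nM, compound 2 `COc1ccc(C(=O)Nc2cccc(/C=C/C(=O)c3nc4ccccc4[nH]3)c2)cc1` gives 4880 nM, and compound 3 `O=C(Nc1cccc(/C=C/C(=O)c2nc3ccccc3[nH]2)c1)c1cc(Cl)cc(Cl)c1` gives 1650 nM. Compound 3 has the lowest number of the three, but the step of a 1.0-fold lower number from compound 1 to compound 3 (0.01 log units; within the scatter) is within the scatter, so the two cannot be separated; the gap is a 3.0-fold lower number from compound 2 to compound 3 (0.47 log units; beyond the scatter), and from compound 1 to compound 2 the step is a 2.9-fold higher number from compound 1 to compound 2 (0.46 log units; beyond the scatter).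

Compound 4 `O=C(/C=C/c1cccc(NS(=O)(=O)c2ccccc2Cl)c1)c1nc2ccccc2[nH]1` differs from compound 3 by (2-chlorophenyl)sulfonyl in place of (3,5-dichlorophenyl)carbonyl on a nitrogen on an aromatic ring. Among the compounds with values here, the measured steps bear on it only in part: swapping the aryl substitution pattern on the carbonyl gave at most a modest step, as in a 3.0-fold lower number from compound 2 to compound 3 (0.47 log units; beyond the scatter) and a 1.0-fold lower number from compound 1 to compound 3 (0.01 log units; within the scatter), but no measured pair tests a sulfonyl in place of the carbonyl. The measured steps do not settle this, so a step of a 1.5-fold higher number from compound 3 to compound 4 (0.18 log units; within the scatter) in this assay is expected, with wide uncertainty. Compound 4 is estimated at 2500 nM, within 900 nM to 7000 nM.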

Compound 4, half-maximal inhibitory concentration: 987 nM
Compound 4: the middle estimate sits 2.5-fold (0.40 log units) above what was measured; low and high end bracket the measured number.
By their numbers in this assay, from the lowest: compounds 4, 3 and 1 (each within the scatter of the next); then compound 2.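

In this assay the nitrogen on an aromatic ring accepts a sulfonyl as well as a carbonyl: a 1.7-fold lower number from compound 3 to compound 4 (0.22 log units; within the scatter) and a 1.7-fold lower number from compound 1 to compound 4 (0.23 log units; within the scatter) both lie within the scatter, so (2-chlorophenyl)sulfonyl cannot be separated from (3,5-dichlorophenyl)carbonyl or (2-bromophenyl)carbonyl at this place. Only against (4-methoxyphenyl)carbonyl does the change register: the step of a 4.9-fold lower number from compound 2 to compound 4 (0.69 log units; beyond the scatter) lies beyond the scatter. Nothing on hand offers an explanation for these steps.

From the compounds shown here alone, each of these pairs changes the aryl substitution together with the sulfonyl, so the contribution of the sulfonyl alone stays open. Also open, going by these compounds, is how this nitrogen would read in this assay with a methylsulfonyl group or a chain ending in an amine in place of the aryl groups.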